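Extending the amine on the aryl ring: compound 3 to compound 4

A few compounds are considered here, and "the series" means these few. Any claim that something is new, unique, unknown or untested is made for them only; others in the source may bear on it.

Measured compounds:
Compound 1, `Cc1cccc(Nc2nccc(-c3cccs3)n2)c1`: 300 nM
Compound 2, `COc1cccc(Nc2nccc(-c3cccs3)n2)c1`: 900 nM
Compound 3, `CN(C)c1cccc(Nc2nccc(-c3cccs3)n2)c1`: 2400 nM

All three compounds share one core and differ only in the group on an aromatic carbon. In a functional assay for inhibition, with Homo sapiens as the target (on this read-out lower numbers stand for stronger inhibition and higher numbers for weaker inhibition), compound 1 gives 300 nM, compound 2 gives 900 nM and compound 3 gives 2400 nM. Compound 3 therefore stands at the highest number of the three: the step of an 8.0-fold higher number from compound 1 to compound 3 (0.90 log units; beyond the scatter) and the step of a 2.7-fold higher number from compound 2 to compound 3 (0.43 log units; beyond the scatter) both run upward, and a 3.0-fold higher number from compound 1 to compound 2 (0.48 log units; beyond the scatter) points the same way.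

Compound 4, `CC1CCN(c2cccc(Nc3nccc(-c4cccs4)n3)c2)CC1`, takes this series one step further on the same carbon: 4-methylpiperidin-1-yl in place of dimethylamino on an aromatic carbon. Within the data shown here, no measured step exchanges one amine for another; the two steps that bear on it are an 8.0-fold higher number from compound 1 to compound 3 (0.90 log units; beyond the scatter) and a 2.7-fold higher number from compound 2 to compound 3 (0.43 log units; beyond the scatter), each a modest rise in number when the group on that carbon was exchanged for a larger one. Compound 4 is therefore expected to give a modest further rise in this assay, a 1.7-fold higher number from compound 3 to compound 4 (0.22 log units; within the scatter), although a result within the scatter of compound 3 would not be surprising. The estimate for compound 4 in this assay is 4000 nM, with a range from 1300 nM to 12000 nM.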

Compound 4, half-maximal inhibitory concentration: 3500 nM
The estimate for compound 4 lay 1.1-fold (0.06 log units) above the measured number; low and high end bracket the measured number.
By their numbers in this assay, from the lowest: compound 1; then compound 2; then compounds 3 and 4 (each within the scatter of the next).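

In this assay, replacing dimethylamino with 4-methylpiperidin-1-yl, which brings a six-membered non-aromatic ring and more heavy atoms, gives a 1.5-fold higher number from compound 3 to compound 4 (0.16 log units; within the scatter) and so stays within the scatter, whereas every step among the first three compounds lay beyond it. The link between a larger group and a higher number, seen in those steps, therefore does not carry through this last exchange, and compound 4 goes against it; this carbon tolerates the ring with no change that can be told from the scatter. Among these compounds, the wider gaps remain, with a 3.9-fold higher number from compound 2 to compound 4 (0.59 log units; beyond the scatter) beyond the scatter and a 12-fold higher number from compound 1 to compound 4 (1.07 log units; beyond the scatter) the only large step in the set, so both amines sit well apart from the methyl group of compound 1 on this read-out. Nothing measured here accounts for these results.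

From the compounds shown here alone, what piperidin-1-yl without the methyl, a morpholine or a piperazine would give on this carbon stays open, as does whether the methyl of 4-methylpiperidin-1-yl plays any part in the result. Going by these compounds, it is also open whether an ethyl group or a chlorine atom in the same place would match or improve on the methyl group of compound 1 in this assay on this carbon.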